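From chloro to acetamido in a cytotoxicity series

A few compounds are considered here, and "the series" means these few. Any claim that something is new, unique, unknown or untested is made for them only; others in the source may bear on it.

Three close relatives have been measured in an ADME assay on L02 cells (Homo sapiens) for cytotoxicity, read by MTT assay, with a stated time of 24 h; on this read-out higher numbers stand for weaker inhibition and lower numbers for stronger inhibition. Compound 3 `O=C1/C(=C/c2cccnc2)CN(S(=O)(=O)c2ccc(Cl)cc2)C/C1=C\c1ccccc1F` gives > 20000 nM, which is a limit of the assay and not a number. Compound 1 `O=C1/C(=C/c2cccnc2)CN(S(=O)(=O)c2ccc([N+](=O)[O-])cc2)C/C1=C\c1ccccc1F` also gives a limit, > 20000 nM. Compound 2 `O=C1/C(=C/c2cccnc2)CN(S(=O)(=O)c2ccc(F)cc2)C/C1=C\c1ccccc1F` is the only one of the three with a true number, at 15600 nM. The series therefore sits close to the limit of > 20000 nM in this assay, at which 2 of the 3 values shown sit.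

Compound 4 `CC(=O)Nc1ccc(S(=O)(=O)N2C/C(=C\c3cccnc3)C(=O)/C(=C/c3ccccc3F)C2)cc1` differs from compound 3 in one place: acetamido in place of chloro on an aromatic carbon. Acetamido stands in place of chloro on an aromatic carbon, para to a large group. Among the compounds with values here, no measured step makes this exact swap, so the nearest guides are the swaps among nitro, fluoro and chloro at that same place. These give an at least 1.2-fold lower number from compound 1 to compound 2 (0.10 log units; that floor lies within the scatter) and an at least 1.2-fold higher number from compound 2 to compound 3 (0.10 log units; that floor lies within the scatter), while a step that the two limits leave unreadable from compound 1 to compound 3 cannot be sized at all. Since neither readable step is shown to go beyond the scatter, no step of clear size or direction is expected in this assay, although acetamido is a larger change than those swaps. The estimated change is an at least 1.1-fold lower number from compound 3 to compound 4 (0.04 log units; that floor lies within the scatter). For compound 4 the expected value is 18000 nM, within an estimated range of 9000 nM to 35000 nM.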

Compound 4, half-maximal inhibitory concentration: 15600 nM
Compound 4: the middle estimate sits 1.2-fold (0.06 log units) above what was measured; the range from low to high includes it.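

At this position on the sulfonyl-bound aromatic ring, the swap to acetamido is far larger by heavy-atom count than the swaps among nitro, fluoro and chloro, and it adds a hydrogen-bond donor and acceptor. Even so, this assay shows no change at the digits printed from compound 2 to compound 4 (within the scatter), so the earlier compounds' small substituents were not the only ones compatible with a readable value in this series. The other two comparisons give an at least 1.2-fold lower number from compound 3 to compound 4 (0.10 log units; that floor lies within the scatter) and an at least 1.2-fold lower number from compound 1 to compound 4 (0.10 log units; that floor lies within the scatter); each starts from a limit, so it gives only a smallest possible size, and neither shows a change beyond the scatter.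

An amine, a carboxylic acid or a longer chain at this position could show whether any group here moves the value clearly away from that of compound 2, and the compounds shown cannot answer that. How far compounds 1 and 3 truly differ from compound 4 also remains unknown, and the top of the measurable range restricts every comparison with them: the limit of > 20000 nM in this assay, at which 2 of the 4 values shown sit.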